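The compounds below may be only part of what the source reports. "The series", "measured", "known", "first", "only" and "open" are said of these compounds alone.

Among the measured compounds shown here, compound 3 `COc1cc(-c2nn(-c3cccc(NC(=O)Nc4ccc(Cl)c(Cl)c4)c3)cc2-c2ccncc2)ccc1Cl` holds the only number in a functional assay on CAKI-1 cells (Homo sapiens) for inhibition, read by sulforhodamine B assay, with a stated time of 48 h; a lower number here means a stronger inhibitor of growth, a higher number a weaker inhibitor of growth: compound 3 gives 3700 nM. Compound 2 `COc1cc(-c2nn(-c3cccc(NC(=O)c4cccc(C(F)(F)F)c4)c3)cc2-c2ccncc2)ccc1Cl` sits at a limit of this assay, > 50000 nM. Compound 1 `O=C(Nc1cccc(-n2cc(-c3ccncc3)c(-c3ccc(Cl)c(O)c3)n2)c1)Nc1cccc(C(F)(F)F)c1` likewise sits at a limit of this assay, > 32500 nM. For the measured compounds named here, the one measured step, an at least 13-fold lower number from compound 2 to compound 3 (1.13 log units; beyond the scatter), changes the group on the carbonyl carbon, not the oxygen on the aromatic ring, so it does not bear directly on the change examined here. Compound 4 `O=C(Nc1cccc(-n2cc(-c3ccncc3)c(-c3ccc(Cl)c(O)c3)n2)c1)Nc1ccc(Cl)c(Cl)c1` differs from compound 3 by hydrogen in place of methyl on an oxygen on an aromatic ring. Going by the values given here, no measured step covers this change; compound 1 carries the same hydroxy group but also a different group on the carbonyl carbon, and since its value is a limit it sets no direction for the hydroxy change on its own. With nothing measured at this position, the expectation in this assay is a step within the scatter, a 1.4-fold higher number from compound 3 to compound 4 (0.13 log units; within the scatter). Compound 4 is therefore estimated at 5000 nM, with a range of 1500 nM to 20000 nM.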

Compound 4, concentration for total growth inhibition: 14300 nM
Beside the measured number, compound 4's estimate is 2.9-fold (0.46 log units) below it; the range from low to high includes it.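

In this assay, the methoxy to hydroxy change now has a measured direction with the 3,4-dichlorophenyl group held fixed: a 3.9-fold higher number from compound 3 to compound 4 (0.59 log units; beyond the scatter). At this position on the aromatic ring, hydrogen in place of methyl on the oxygen therefore gives the weaker inhibitor of growth of this pair. With the hydroxy group held fixed, the other new step, an at least 2.2-fold lower number from compound 1 to compound 4 (0.35 log units; beyond the scatter), favours 3,4-dichlorophenyl over 3-(trifluoromethyl)phenyl, but it starts from a limit of the assay, not a number: the limit of > 32500 nM in this assay, at which 1 of the 4 values shown sits.

Whether the methoxy to hydroxy step keeps its direction and size with 3-(trifluoromethyl)phenyl in place stays open, since the compounds shown include no methoxy partner of compound 1 in the same series. Going by these compounds, how an ethoxy group or an amino group would read at this position also stays open.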